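Ethoxycarbonyl in Place of Chloro: Cytotoxicity Expectation

The source may hold more compounds than are shown below. What is called first, only, known or untested is meant among the compounds shown, and "the series" means these compounds.

The series shares one core and differs at the amide-type nitrogen. Compound 1 `O=C(CCc1cccc2c1B(O)OC2)NC1CCCCC1` carries a cyclohexyl there. In an ADME assay on WI-38 cells (Homo sapiens) for cytotoxicity, read by MTT assay, with a stated time of 72 h (on this read-out lower numbers stand for stronger inhibition and higher numbers for weaker inhibition), compound 1 gives > 100000 nM, which is a limit of the assay and not a number. Compound 2 `O=C(CCc1cccc2c1B(O)OC2)Nc1ccc(Cl)cc1` carries a 4-chlorophenyl instead. In this assay compound 2 likewise gives > 100000 nM, again a limit rather than a number. The step that the two limits leave unreadable from compound 1 to compound 2 therefore cannot be read in size, since both values sit at the limit of > 100000 nM in this assay, at which 2 of the 2 values shown sit. Compound 2 thus stands at the limit, as does every value shown so far.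

Compound 3 `CCOC(=O)c1ccc(NC(=O)CCc2cccc3c2B(O)OC3)cc1` differs from compound 2 by ethoxycarbonyl in place of chloro on an aromatic carbon. No measured step speaks directly to this change; the only step shown, from cyclohexyl to 4-chlorophenyl, is itself unreadable. With both measured compounds at the limit, the writer expects no step beyond the scatter in this assay, and expects the step of a number no higher from compound 2 to compound 3 (the limit leaves the size open) to leave the value at the limit as well. Compound 3 is therefore estimated at 100000 nM, within 50000 nM to 300000 nM.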

Compound 3, half-maximal inhibitory concentration: > 100000 nM
Compound 3 was reported as a limit; the forecaster's own chance of this, stated with the estimate: 85%; the middle value sits exactly at the limit.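

In this assay compound 3 gives > 100000 nM, which is a limit and not a number. Within the data shown here, compound 2 and compound 3 therefore yield no new step that can be read: the limit of > 100000 nM in this assay, at which 3 of the 3 values shown sit. The compounds shown leave open how far each lies from that limit, and whether either change alters cytotoxicity at all.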